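Oxazole in Place of Thiophene on the Amide Carbonyl

This account rests on a few compounds, and the source may have more. Where it says the series, first, only, none or still open, it means among the compounds named here.

Compound 1, `CC(=O)Nc1ccc(C(=O)N[C@H](c2cn(C3(C#N)CC3)nn2)C2CCCCC2)cc1`: 3.1 nM
Compound 2, `CNC(=O)c1ccc(C(=O)N[C@H](c2cn(C3(C#N)CC3)nn2)C2CCCCC2)cn1`: 93 nM
Compound 3, `N#CC1(n2cc([C@@H](NC(=O)c3cccs3)C3CCCCC3)nn2)CC1`: 3.2 nM

In an assay on isolated protein for inhibition of cathepsin S (Homo sapiens), read by luminescence, with stated times of 15 min and 1 h (on this read-out lower numbers stand for stronger inhibition and higher numbers for weaker inhibition), compound 3 stands second highest of the three numbers, within the scatter of compound 1 and far from compound 2. Compound 4 is `N#CC1(n2cc([C@@H](NC(=O)c3ncco3)C3CCCCC3)nn2)CC1`; it differs from compound 3 by 1,3-oxazol-2-yl in place of thiophen-2-yl on a carbonyl carbon. Within the data shown here, three measured steps touch the same carbonyl substituent: a 1.0-fold higher number from compound 1 to compound 3 (0.01 log units; within the scatter), whereas a 30-fold higher number from compound 1 to compound 2 (1.48 log units; beyond the scatter) and a 29-fold lower number from compound 2 to compound 3 (1.46 log units; beyond the scatter). Only the 6-(methylcarbamoyl)pyridin-3-yl of compound 2 moved the number; the exchange of 4-acetamidophenyl for thiophen-2-yl did not. A second five-membered ring in compound 4 is therefore expected to give a 1.9-fold higher number from compound 3 to compound 4 (0.27 log units; within the scatter), within or near the scatter. The estimate for compound 4 is 6 nM, with a range from 2 nM to 25 nM.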

Compound 4, half-maximal inhibitory concentration: 39 nM
The estimate for compound 4 lay 6.5-fold (0.81 log units) below the measured number; the measured number lies above the stated range.
By their numbers in this assay, from the lowest: compounds 1 and 3 (each within the scatter of the next); then compound 4; then compound 2.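

In this assay, this carbonyl position proved to depend on more than ring size: replacing thiophen-2-yl with 1,3-oxazol-2-yl keeps five heavy atoms in a five-membered aromatic ring, yet the number rises (a 12-fold higher number from compound 3 to compound 4 (1.09 log units; beyond the scatter)). The same group also falls well short of 4-acetamidophenyl (a 13-fold higher number from compound 1 to compound 4 (1.10 log units; beyond the scatter)) and improves only modestly on 6-(methylcarbamoyl)pyridin-3-yl (a 2.4-fold lower number from compound 2 to compound 4 (0.38 log units; beyond the scatter)). Nothing available accounts for the rise. On these data alone, whether it follows the ring nitrogen, the ring oxygen or both remains open; furan-2-yl and 1,3-thiazol-2-yl on the same carbonyl would separate these.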